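Swapping a Methyl for a Fluorophenylamino Group

This account rests on a few compounds, and the source may have more. Where it says the series, first, only, none or still open, it means among the compounds named here.

Compound 1, `CCCOc1ccc(C(=O)Nc2cccc(C)n2)cc1`: in an in vitro assay on HEK-tsA201 cells for antagonist activity at Neuronal acetylcholine receptor; alpha3/beta4 (Homo sapiens), read by fluorescence and calcium flux (on this read-out lower numbers stand for stronger inhibition and higher numbers for weaker inhibition), compound 1 gives 11100 nM.
Compound 2, `CCCNc1cccc(NC(=O)c2ccc(OCCC)cc2)n1`: in this assay compound 2 gives 12600 nM.
Compound 3, `CCCCCCNc1cccc(NC(=O)c2ccc(OCCC)cc2)n1`: in this assay compound 3 reaches only a limit, > 100000 nM, and no number.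

Compound 1 has the lowest of the two numbers recorded, but compound 2 sits right beside it, since the step of a 1.1-fold higher number from compound 1 to compound 2 (0.06 log units; within the scatter) stays within the scatter. Compound 4, `CCCOc1ccc(C(=O)Nc2cccc(Nc3ccc(F)cc3)n2)cc1`, differs from compound 1 in one place: (4-fluorophenyl)amino in place of methyl on an aromatic carbon. Two measured steps already replace the same methyl with a larger group on that aromatic carbon. The propylamino change, a 1.1-fold higher number from compound 1 to compound 2 (0.06 log units; within the scatter), did not move the number beyond the scatter, whereas the hexylamino change, an at least 9.0-fold higher number from compound 1 to compound 3 (0.95 log units; beyond the scatter), pushed the compound to the limit of the assay, (the limit of > 100000 nM in this assay, at which 1 of the 3 values shown sits). Lengthening the chain alone also did so, an at least 7.9-fold higher number from compound 2 to compound 3 (0.89 log units; beyond the scatter). The (4-fluorophenyl)amino group is bulkier than propylamino yet is a ring rather than a long chain, so the pattern is not settled by these three compounds. A modest weakening in this assay is expected, a 2.3-fold higher number from compound 1 to compound 4 (0.35 log units; beyond the scatter), with a real chance that only a limit is returned. Compound 4 is estimated at 25000 nM, between 6000 nM and 100000 nM.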

Compound 4, half-maximal inhibitory concentration: > 100000 nM
Compound 4 ended at the assay's limit; the forecaster's own chance of this, stated with the estimate: 30%; middle value at least 4.0-fold (0.60 log units) away from the limit.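

At this position, on an aromatic carbon next to the ring nitrogen, a ring carried on the amino nitrogen weakens inhibition as much as this assay can show, with an at least 9.0-fold higher number from compound 1 to compound 4 (0.95 log units; beyond the scatter). Exchanging the propyl on that nitrogen for 4-fluorophenyl gives an at least 7.9-fold higher number from compound 2 to compound 4 (0.89 log units; beyond the scatter), so the loss seen with compound 3 does not need a long chain, and of the three replacements of the methyl only the propylamino of compound 2 stays within the scatter of compound 1. Compound 3 and compound 4 both stop at a limit rather than a number, so the step between them cannot be read and the two cannot be ranked: the limit of > 100000 nM in this assay, at which 2 of the 4 values shown sit.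

The compounds shown leave open where, between propylamino and these two larger groups, the number begins to climb, for instance with a butylamino chain or a cyclopropylamino group. They also leave open whether the fluorine plays any part, which a plain phenylamino group or a 4-methoxyphenylamino group in the same place could begin to answer.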